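Acetyl in place of phenoxy: working notes

The source may report more compounds than this note shows. Statements on the series, on what has been measured and on what is new or still open speak of the compounds shown alone.

Values in a functional assay on DU-145 cells (Homo sapiens) for inhibition, read by trypan blue exclusion, with a stated time of 96 h; on this read-out lower numbers stand for stronger inhibition of growth and higher numbers for weaker inhibition of growth:
- compound 1 `CSc1ccc(/C=C(/Sc2ccc(C)cc2)C(=O)c2ccc(Br)cc2)cc1`: 50000 nM
- compound 2 `COc1ccccc1/C=C(/Sc1ccc(C)cc1)C(=O)c1ccc(Br)cc1`: 9000 nM
- compound 3 `Cc1ccc(S/C(=C/c2ccc(Oc3ccccc3)cc2)C(=O)c2ccc(Br)cc2)cc1`: 1000 nM

Compound 3 stands lowest of the three numbers, and both other compounds sit beyond the scatter from it. Compound 4 `CC(=O)c1ccc(/C=C(/Sc2ccc(C)cc2)C(=O)c2ccc(Br)cc2)cc1` differs from it by acetyl in place of phenoxy on an aromatic carbon, with acetyl in place of phenoxy on an aromatic carbon, para to a large group. The closest evidence is a 50-fold lower number from compound 1 to compound 3 (1.70 log units; beyond the scatter), a large step that introduces phenoxy in place of methylsulfanyl. The modest 5.6-fold lower number from compound 1 to compound 2 (0.74 log units; beyond the scatter) bears only loosely. Among the measured compounds shown here, no measured compound carries acetyl, so losing phenoxy is expected to raise the number in this assay. The expected change is an 8.0-fold higher number from compound 3 to compound 4 (0.90 log units; beyond the scatter). For compound 4 the estimate is 8000 nM, within an expected range of 2000 nM to 35000 nM.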

Compound 4, concentration for 50% growth inhibition: 50000 nM
The estimate for compound 4 lay 6.3-fold (0.80 log units) below the measured number, outside the stated range (above it).
By their numbers in this assay, from the lowest: compound 3; then compound 2; then compounds 1 and 4 (each within the scatter of the next).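

In this assay acetyl in place of phenoxy gives a 50-fold higher number from compound 3 to compound 4 (1.70 log units; beyond the scatter) and acetyl in place of methylsulfanyl gives no change at the digits printed from compound 1 to compound 4 (within the scatter) at this aromatic carbon, so of these three groups only phenoxy carries the lower number here. The exchange of 2-methoxyphenyl for 4-acetylphenyl gives a 5.6-fold higher number from compound 2 to compound 4 (0.74 log units; beyond the scatter) on the same chain carbon, so acetyl also falls short of the 2-methoxyphenyl compound. Nothing available accounts for the gap between phenoxy and acetyl. Going by these compounds, whether benzyloxy, a phenyl ring bound directly, or a dimethylamino group at this place would hold the lower number stays open.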